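Amine side-chain variation and cytotoxicity in the diarylether series

The source may report more compounds than this note shows. Statements on the series, on what has been measured and on what is new or still open speak of the compounds shown alone.

Of the compounds shown here, three have been measured in an ADME assay on MT4 cells (Homo sapiens) for cytotoxicity, read by MTT assay, with a stated time of 5 days; on this read-out lower numbers stand for higher toxicity in this test and higher numbers for lower toxicity in this test. Compound 1 `Cc1cc(/C=C/C#N)cc(C)c1Oc1cc(NCCN2CCN(C)CC2)nc(Nc2ccc(C#N)cc2)c1` gives 7960 nM. Compound 2 `COC(Nc1cc(Oc2c(C)cc(/C=C/C#N)cc2C)nc(Nc2ccc(C#N)cc2)n1)OC` gives 3470 nM, the lowest of the three numbers. Compound 3 `COCCNc1cc(Oc2c(C)cc(/C=C/C#N)cc2C)cc(Nc2ccc(C#N)cc2)n1` gives 58200 nM, the highest. For the measured compounds named here, the one single-point step among them, a 7.3-fold higher number from compound 1 to compound 3 (0.86 log units; beyond the scatter), shows that altering the chain on the aromatic amine nitrogen moves this read-out by a modest but real amount, towards higher numbers when the chain is trimmed to a small ether.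

Compound 4 `Cc1cc(/C=C/C#N)cc(C)c1Oc1cc(NCC2CCCO2)nc(Nc2ccc(C#N)cc2)n1` is the next candidate: (oxolan-2-yl)methyl in place of dimethoxymethyl on a nitrogen on an aromatic ring. Going by the values given here, the change again sits on the same aromatic amine nitrogen, so the step from compound 1 to compound 3 is the only comparison that bears on it; the entering group, like that of compound 3, carries a single ether oxygen rather than two. A step of similar modest size towards a higher number, or none beyond the scatter, is therefore expected. On that basis compound 4 is expected to give 8000 nM, within 2500 nM to 30000 nM, an estimated step of a 2.3-fold higher number from compound 2 to compound 4 (0.36 log units; beyond the scatter).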

Compound 4, half-maximal cytotoxic concentration: > 268000 nM
Compound 4 was reported as a limit; the forecaster's own chance of this, stated with the estimate: 5%; at least 33-fold (1.52 log units) between middle value and limit.
By their numbers in this assay, from the lowest: compound 2; then compound 1; then compound 3. At a limit, above all of these: compound 4.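

Placed on a nitrogen on an aromatic ring, (oxolan-2-yl)methyl in place of dimethoxymethyl gives an at least 77-fold higher number from compound 2 to compound 4 (1.88 log units; beyond the scatter) in this assay. For the compounds shown here, this single change is a large step, whereas the only earlier step at this nitrogen was the modest 7.3-fold higher number from compound 1 to compound 3 (0.86 log units; beyond the scatter), so the group on this nitrogen can move the read-out much further than that step showed. Compound 4 stands as a limit of the assay and not as a number: the limit of > 268000 nM in this assay, at which 1 of the 4 values shown sits.

The entering group differs from dimethoxymethyl both in its five-membered non-aromatic ring and in its single hydrogen-bond acceptor, and one pair cannot separate these two differences. Cyclopentylmethyl, which keeps a five-membered ring without the oxygen, and an open-chain group such as 3-methoxypropyl on the same core would bear on that question.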